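The source may hold more compounds than are shown below. What is called first, only, known or untested is meant among the compounds shown, and "the series" means these compounds.

Measured in an ADME assay on NIH3T3 cells (Mus musculus) for cytotoxicity, read by MTT assay, with a stated time of 24 h; a lower number here means a stronger inhibitor, a higher number a weaker inhibitor:
compound 1 `Oc1cccc(/C=N/n2c(S)nnc2-c2cnccn2)c1`: 151000 nM
compound 2 `COc1ccc(/C=N/n2c(S)nnc2-c2cnccn2)cc1OC`: 163000 nM
compound 3 `Sc1nnc(-c2cnccn2)n1/N=C/c1ccc(Cl)cc1Cl`: 206000 nM

Compound 2 stands in the middle of these three numbers, and its gaps to compound 1 and compound 3 both lie within the usual scatter. Compound 4 `COc1cc(/C=N/n2c(S)nnc2-c2cnccn2)cc(OC)c1OC` is compound 2 with one change: methoxy in place of hydrogen on an aromatic carbon. Going by the values given here, no measured pair isolates a change like this one. However, the three measured compounds carry different groups on the same core, and they still lie close together, from compound 1 at 151000 nM to compound 3 at 206000 nM. A step beyond the scatter in this assay is therefore not expected, in either direction. The expected change is a 1.0-fold higher number from compound 2 to compound 4 (0.01 log units; within the scatter). For compound 4 the estimated value is 165000 nM, with an expected range of 90000 nM to 300000 nM.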

Compound 4, half-maximal inhibitory concentration: 169000 nM
Compound 4: the middle estimate sits 1.0-fold (0.01 log units) below what was measured, within the range that was stated.
By their numbers in this assay, from the lowest: compounds 1, 2, 4 and 3 (each within the scatter of the next).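

In this assay, methoxy in place of hydrogen on this aromatic carbon, ortho to a methoxy group, gives a 1.0-fold higher number from compound 2 to compound 4 (0.02 log units; within the scatter) and so produces no measurable shift. Going by these compounds alone, this is the first comparison here in which only one place differs, and it shows that this position accepts one more methoxy group without a step beyond the scatter. No available evidence bears on the reason for this result. As far as these compounds go, whether an amine or a carboxylic acid at this position would also stay within the scatter remains open. The same holds for a longer chain in place of methoxy.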